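A few compounds are considered here, and "the series" means these few. Any claim that something is new, unique, unknown or untested is made for them only; others in the source may bear on it.

Measured compounds:
Compound 1, `COc1ccc(N(C)c2nc(C)nc3ccccc23)cc1OCCN`: 421 nM in a functional assay on LoVo cells (Homo sapiens) for inhibition, read by MTT assay, with a stated time of 48 h; a lower number here means a stronger inhibitor, a higher number a weaker inhibitor
Compound 2, `C[Se]c1ccc(N(C)c2nc(C3CC3)nc3ccccc23)cc1`: 11 nM in this assay
Compound 3, `C[Se]c1ccc(N(C)c2nc(C)nc3ccccc23)cc1C`: 9 nM in this assay

Among these three numbers, compound 1 gives the highest value in this assay. Its nearest neighbour is compound 2, whose number is lower by a margin that lies beyond the scatter, and compound 3 stands further still, also beyond the scatter. Compound 1 is therefore the weakest inhibitor of the three on the numbers shown.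

The unmeasured compound 4, `COc1ccc(N(C)c2nc(C)nc3ccccc23)cc1OCCCCC[Se]C#N`, shares the core of compound 1 and differs from it in one place: a group of 6 heavy atoms (4 carbon, 1 nitrogen, 1 selenium; no ring) in place of one nitrogen atom, on a saturated chain carbon, two bonds along the chain from an oxygen on an aromatic ring. For the measured compounds named here, no step between measured compounds is available for this change, so its size must be judged from the structural change alone and from where compound 1 stands.

A moderate move toward a lower number is expected for compound 4, a step of a 2.8-fold lower number from compound 1 to compound 4 (0.45 log units; beyond the scatter) beyond the scatter, because compound 1 starts from 421 nM and leaves room to improve. The estimate for compound 4 in this assay is 150 nM, within a range from 40 nM to 600 nM.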

Compound 4, half-maximal inhibitory concentration: 5210 nM
The estimate for compound 4 lay 35-fold (1.54 log units) below the measured number; measured number outside the range, above it.
By their numbers in this assay, from the lowest: compounds 3 and 2 (each within the scatter of the next); then compound 1; then compound 4.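

Replacing the amino group with the selenium-bearing nitrile group of 6 heavy atoms, on a saturated chain carbon, two bonds along the chain from an oxygen on an aromatic ring, gives in this assay a 12-fold higher number from compound 1 to compound 4 (1.09 log units; beyond the scatter). This single step shows that the position is not indifferent to what it carries, and that this change leaves a much weaker inhibitor on the same core. Nothing measured here accounts for the size of the step.

The amino group leaves and the new group enters in one step, so the compounds shown cannot tell how much of the loss belongs to each. As far as these compounds go, a longer chain ending in an amine, or a chain ending in a carboxylic acid, remains open at this position.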